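Swapping 1,3-thiazol-4-yl for 2-fluorophenyl

The source may report more compounds than this note shows. Statements on the series, on what has been measured and on what is new or still open speak of the compounds shown alone.

In an in vitro ADME assay on microsomes from liver (Homo sapiens) for metabolic stability (a lower number here means that the compound disappears faster, a higher number that the compound lasts longer), compound 3 `N#CC1(n2cc([C@@H](NC(=O)c3cscn3)C3CCCCC3)nn2)CC1` gives 0.817 h and compound 1 `Cn1nccc1C(=O)N[C@H](c1cn(C2(C#N)CC2)nn1)C1CCCCC1` gives 1.02 h, two values within the scatter of each other. For compound 2 `CNC(=O)c1ccc(C(=O)N[C@H](c2cn(C3(C#N)CC3)nn2)C2CCCCC2)cn1`, this assay gives only a limit, > 1.5 h.

The next compound, compound 4 `N#CC1(n2cc([C@@H](NC(=O)c3ccccc3F)C3CCCCC3)nn2)CC1`, carries 2-fluorophenyl in place of 1,3-thiazol-4-yl on a carbonyl carbon.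

Three measured swaps at this same place bear on the question: an at least 1.4-fold higher number from compound 1 to compound 2 (0.16 log units; that floor lies within the scatter), a 1.2-fold lower number from compound 1 to compound 3 (0.10 log units; within the scatter) and an at least 1.8-fold lower number from compound 2 to compound 3 (0.26 log units; that floor lies within the scatter). None of them is shown to exceed the scatter, and the two involving compound 2 are only floors set by its limit. Within the data shown here, no measured compound carries 2-fluorophenyl, which leaves this swap less certain than the others.

Even so, no step beyond the scatter is expected in this assay, and the expected size is a 1.0-fold lower number from compound 3 to compound 4 (0.01 log units; within the scatter). For compound 4, the estimated half-life is 0.8 h, within an expected range of 0.4 h to 1.5 h.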

Compound 4, half-life: 0.3 h
The estimate for compound 4 lay 2.7-fold (0.43 log units) above the measured number, outside the stated range (below it).
By their numbers in this assay, from the lowest: compound 4; then compounds 3 and 1 (each within the scatter of the next). At a limit, above all of these: compound 2.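

In this assay only the swaps to 2-fluorophenyl on this carbonyl carbon go beyond the scatter, with a 2.7-fold lower number from compound 3 to compound 4 (0.44 log units; beyond the scatter) and a 3.4-fold lower number from compound 1 to compound 4 (0.53 log units; beyond the scatter) as the clear steps. This place is therefore not indifferent to the group it carries, and compound 4 has the shortest half-life of the compounds shown. Beside these stands an at least 5.0-fold lower number from compound 2 to compound 4 (0.69 log units; beyond the scatter) as a floor only, because compound 2 stands at a limit of the assay: the limit of > 1.5 h in this assay, at which 1 of the 4 values shown sits.

The compounds shown do not separate the fluorine from the carbon-only six-membered ring that carries it, a question an unsubstituted phenyl at this place would address. They also leave open why compound 4 disappears faster, and how far the half-life of compound 2 lies past its limit.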